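Swapping the amide substituent of a dienamide series

The source may report more compounds than this note shows. Statements on the series, on what has been measured and on what is new or still open speak of the compounds shown alone.

Measured compounds:
compound 1, `COc1ccc(CNC(=O)/C=C/C=C/[C@H](O)Cc2ccc(OC)c(OC)c2)cc1`, 9450 nM
compound 2, `CCN1CCN(C(=O)/C=C/C=C/[C@H](O)Cc2ccc(OC)c(OC)c2)CC1`, 11700 nM
compound 3, `CCNC(=O)/C=C/C=C/[C@H](O)Cc1ccc(OC)c(OC)c1`, 14600 nM

In a functional assay on HeLa cells (Homo sapiens) for antiproliferative activity, read by sulforhodamine B assay, with a stated time of 48 h (on this read-out lower numbers stand for stronger inhibition and higher numbers for weaker inhibition), compound 3 stands highest of the three numbers, yet both steps leading to it, a 1.5-fold higher number from compound 1 to compound 3 (0.19 log units; within the scatter) and a 1.2-fold higher number from compound 2 to compound 3 (0.10 log units; within the scatter), lie within the scatter, so the three compounds cannot be ranked. Compound 4, `COc1ccc(C[C@@H](O)/C=C/C=C/C(=O)NCc2ccc(Cl)cc2)cc1OC`, differs from compound 3 by 4-chlorophenyl in place of methyl on a saturated chain carbon bound to an amide-type nitrogen. Going by the values given here, the one measured step that bears on this, a 1.5-fold higher number from compound 1 to compound 3 (0.19 log units; within the scatter), went the opposite way at the same place, from 4-methoxyphenyl to methyl, and was within the scatter. A step back toward a benzyl-type amide is therefore expected to be small, a 1.5-fold lower number from compound 3 to compound 4 (0.19 log units; within the scatter), no clear direction. Compound 4 is estimated at 9500 nM, in the range 4000 nM to 22000 nM.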

Compound 4, half-maximal inhibitory concentration: 13400 nM
For compound 4 the middle estimate is 1.4-fold (0.15 log units) below the measured one, within the range that was stated.
By their numbers in this assay, from the lowest: compounds 1, 2, 4 and 3 (each within the scatter of the next).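

Putting 4-chlorophenyl, with seven heavy atoms and an aromatic ring, in place of the single carbon of methyl leaves the two compounds within the scatter (a 1.1-fold lower number from compound 3 to compound 4 (0.04 log units; within the scatter)). (4-Chlorobenzyl)amino in place of 4-ethylpiperazin-1-yl (a 1.1-fold higher number from compound 2 to compound 4 (0.06 log units; within the scatter)) and chloro in place of methoxy on an aromatic carbon (a 1.4-fold higher number from compound 1 to compound 4 (0.15 log units; within the scatter)) also stay within it, so none of the four amide substituents separates from the others. Nothing available explains this.

Still open, as far as these compounds go, is whether an amine, a carboxylic acid or a longer chain on a saturated chain carbon bound to an amide-type nitrogen would move the number beyond the scatter.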